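A few compounds are considered here, and "the series" means these few. Any claim that something is new, unique, unknown or untested is made for them only; others in the source may bear on it.

Compound 1 `CCCCC1([C@H](O)/C=C/C2CCC(=O)[C@@H]2CCCCCC(=O)O)CCC1`: 0.32 mg/kg
Compound 2 `CCCCC1([C@H](O)/C=C/C2[C@H](O)CC(=O)[C@@H]2CCCCCCC(=O)O)CCC1`: 0.00145 mg/kg

In a functional assay on the whole organism (strain Hartley) for inhibition, with Cavia porcellus as the target, with stated times of 15 min and 2 min (on this read-out higher numbers stand for an effect only at larger amounts of compound and lower numbers for an effect already at smaller amounts), compound 2 gives the lowest number of the two measured compounds, and compound 1 stands far above it, well beyond the usual scatter. Compound 3 `CCCCC1([C@H](O)/C=C/C2CCC(=O)[C@@H]2CCCCCCC(=O)O)CCC1` has not yet been measured. The change from compound 2 to compound 3 is hydrogen in place of hydroxy on a saturated ring carbon. Among the compounds with values here, no measured pair shows this change directly, so its size is unknown from the data. Because compound 1 gives 0.32 mg/kg while also lacking the hydroxy, a large step toward a higher number is expected, a 69-fold higher number from compound 2 to compound 3 (1.84 log units; beyond the scatter). Compound 3 is estimated at 0.1 mg/kg, within 0.01 mg/kg to 1 mg/kg.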

Compound 3, dose for half-maximal effect: 47.8 mg/kg
Compound 3: the middle estimate sits 480-fold (2.68 log units) below what was measured, and the stated range ends below it.
By their numbers in this assay, from the lowest: compound 2; then compound 1; then compound 3.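

Replacing hydroxy with hydrogen on this saturated ring carbon in this assay gives a 33000-fold higher number from compound 2 to compound 3 (4.52 log units; beyond the scatter), so the hydroxy matters far more here than compound 1 alone suggested. Without the hydroxy, the chain matters too: carboxymethyl in place of carboxy gives a 150-fold higher number from compound 1 to compound 3 (2.17 log units; beyond the scatter). Nothing available explains why either change has such a large effect. Going by these compounds, whether a methoxy or an amine on this ring carbon would keep the number as low as in compound 2 remains open. So does the size of the chain step with the hydroxy present.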